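Swapping a basic piperidine for a methylsulfonyl piperazine

The source may hold more compounds than are shown below. What is called first, only, known or untested is meant among the compounds shown, and "the series" means these compounds.

Measured compounds:
compound 1, `COc1cc(N)c(Cl)cc1C(=O)NC1CCN(CCCCCN2CCCCC2)CC1`, 5.01 nM
compound 2, `COc1cc(N)c(Cl)cc1C(=O)NC1CCN(CCCCCCCCN2CCCCC2)CC1`, 3.16 nM
compound 3, `COc1cc(N)c(Cl)cc1C(=O)NC1CCN(CCN2CCN(S(C)(=O)=O)CC2)CC1`, 20 nM

All three share one core and differ only in the chain that hangs from the ring amine. In a functional assay on HEK293 cells for agonist activity at 5-hydroxytryptamine receptor 4 (Homo sapiens), read by cAMP accumulation (a higher number here means that more compound is needed for the effect, a lower number that less compound is needed), compound 1 gives 5.01 nM. Compound 2 differs from compound 1 by 3-(piperidin-1-yl)propyl in place of piperidin-1-yl on a saturated chain carbon, five bonds along the chain from an amine nitrogen in a ring, and this gave a 1.6-fold lower number from compound 1 to compound 2 (0.20 log units; within the scatter). Compound 3 differs from compound 1 by 4-(methylsulfonyl)piperazin-1-yl in place of 3-(piperidin-1-yl)propyl on a saturated chain carbon, two bonds along the chain from an amine nitrogen in a ring, which gave a 4.0-fold higher number from compound 1 to compound 3 (0.60 log units; beyond the scatter).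

Compound 4, `COc1cc(N)c(Cl)cc1C(=O)NC1CCN(CCCCCN2CCN(S(C)(=O)=O)CC2)CC1`, has not yet been measured in this assay. It differs from compound 2 by 4-(methylsulfonyl)piperazin-1-yl in place of 3-(piperidin-1-yl)propyl on a saturated chain carbon, five bonds along the chain from an amine nitrogen in a ring. This is the same kind of change as that from compound 1 to compound 3, but the place is not the same: there the group sits two bonds along the chain from the amine nitrogen in a ring, here five bonds along. Among the compounds with values here, because compound 3 showed a 4.0-fold higher number from compound 1 to compound 3 (0.60 log units; beyond the scatter), a step of similar size is expected here, a 3.5-fold higher number from compound 2 to compound 4 (0.54 log units; beyond the scatter), though only one such pair has been seen, so the range is kept wide. Compound 4 is therefore estimated at 11 nM, between 4 nM and 32 nM.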

Compound 4, half-maximal effective concentration: 12.6 nM
The estimate for compound 4 lay 1.1-fold (0.06 log units) below the measured number; measured number inside the range.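

Replacing 3-(piperidin-1-yl)propyl with 4-(methylsulfonyl)piperazin-1-yl gave a 4.0-fold higher number from compound 2 to compound 4 (0.60 log units; beyond the scatter) in this assay, so the change carried over from one core to another with its size intact: the same change on two cores in this assay, a 4.0-fold higher number (0.60 log units; beyond the scatter) from compound 1 to compound 3 and a 4.0-fold higher number (0.60 log units; beyond the scatter) from compound 2 to compound 4, 1.0-fold (0.00 log units) apart, within the scatter of two such steps. Within the data shown here, this agreement rests on only two pairs, so it is no general rule for the series, and it does not explain why more compound is needed after the change. Each of these two steps also alters the chain as well as the end group, whereas keeping the chain and swapping only piperidin-1-yl for 4-(methylsulfonyl)piperazin-1-yl gives the smaller 2.5-fold higher number from compound 1 to compound 4 (0.40 log units; beyond the scatter), though still beyond the scatter.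

The compounds shown leave open whether a similar step would appear with a morpholine or an unsubstituted piperazine at the end of the chain. Among these compounds, they also leave open how 4-(methylsulfonyl)piperazin-1-yl would behave on a longer chain, such as the one in compound 2.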